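Amide substituent changes on the shared core

A few compounds are considered here, and "the series" means these few. Any claim that something is new, unique, unknown or untested is made for them only; others in the source may bear on it.

Measured compounds:
compound 1, `CCn1c(C(=O)NCCN)ccc1C(CC)(CC)c1ccc(OCCC(O)(CC)CC)c(C)c1`: 2420 nM
compound 2, `C=CCN(C)C(=O)c1ccc(C(CC)(CC)c2ccc(OCCC(O)(CC)CC)c(C)c2)n1CC`: 12800 nM
compound 3, `CCn1c(C(=O)Nc2ccc(OC(F)(F)F)cc2)ccc1C(CC)(CC)c1ccc(OCCC(O)(CC)CC)c(C)c1`: > 50000 nM, a limit of the assay

Within the data shown here, in a functional assay on PC-3 cells (Homo sapiens) for antiproliferative activity, read by MTT assay, with a stated time of 48 h (a higher number here means a weaker inhibitor, a lower number a stronger inhibitor), compound 1 holds the lowest of the two numbers known. Compound 2 sits higher, a 5.3-fold higher number from compound 1 to compound 2 (0.72 log units; beyond the scatter). For compound 3 the assay returns only a limit, (the limit of > 50000 nM in this assay, at which 1 of the 3 values shown sits), so the steps of an at least 20-fold higher number from compound 1 to compound 3 (1.31 log units; beyond the scatter) and an at least 3.9-fold higher number from compound 2 to compound 3 (0.59 log units; beyond the scatter) are bounds rather than exact sizes. Both measured changes replace the (2-aminoethyl)amino group and both move the number upward.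

Compound 4, `CCOC(=O)CN(C)C(=O)c1ccc(C(CC)(CC)c2ccc(OCCC(O)(CC)CC)c(C)c2)n1CC`, is the next member. Against compound 1 the difference is ((ethoxycarbonyl)methyl)(methyl)amino in place of (2-aminoethyl)amino on a carbonyl carbon. Among the measured compounds shown here, of the measured steps, the one from compound 1 to compound 2 bears most closely on it: compound 2 and compound 4 both carry a methyl-bearing amino group on the carbonyl carbon in place of (2-aminoethyl)amino, and that step was modest and upward. Compound 3 shows that a larger change at the same place can push the number past the assay limit, but compound 4 stays closer to compound 2 in size. A modest upward step is therefore expected, a 5.0-fold higher number from compound 1 to compound 4 (0.70 log units; beyond the scatter). Compound 4 is estimated at 12000 nM, within 4000 nM to 40000 nM.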

Compound 4, half-maximal inhibitory concentration: 7140 nM
Estimate against measurement, compound 4: 1.7-fold (0.23 log units) above, within the range that was stated.
By their numbers in this assay, from the lowest: compound 1; then compounds 4 and 2 (each within the scatter of the next). At a limit, above all of these: compound 3.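

In this assay, the change at the end of the methyl-bearing amide chain carries little weight: a 1.8-fold lower number from compound 2 to compound 4 (0.25 log units; within the scatter), so ethoxycarbonyl in place of vinyl on that saturated chain carbon gives no order between these two compounds. Against the (2-aminoethyl)amino group of the shared core, the ester-bearing replacement still gives a 3.0-fold higher number from compound 1 to compound 4 (0.47 log units; beyond the scatter), which makes three different replacements on this carbonyl carbon that all leave the number higher, with none among the compounds shown going against this. The aryl amide remains apart from the ester-bearing amide, although the step of an at least 7.0-fold lower number from compound 3 to compound 4 (0.84 log units; beyond the scatter) is a bound and not an exact size: the limit of > 50000 nM in this assay, at which 1 of the 4 values shown sits.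

Going by these compounds, whether the lower number of compound 1 depends on the amine of its side chain, on the amide hydrogen, or on both remains open, and a (2-aminoethyl)(methyl)amino group or a (2-hydroxyethyl)amino group on the same carbonyl carbon would separate these. A carboxylic acid in place of the ethyl ester of compound 4, or a longer chain between the amide nitrogen and the amine of compound 1, would test how far this position tolerates further change.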